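This account rests on a few compounds, and the source may have more. Where it says the series, first, only, none or still open, it means among the compounds named here.

Measured in an ADME assay on MT4 cells (Homo sapiens) for cytotoxicity, read by MTT assay, with a stated time of 5 days; a lower number here means that less compound is tolerated, a higher number that more compound is tolerated:
- Compound 1 `O=C(CSc1ncnn1-c1ccc(Cl)cc1Cl)Nc1ccccc1Br`: 95100 nM
- Compound 2 `Cc1ccc(NC(=O)CSc2ncnn2-c2ccc(Cl)cc2Cl)c([N+](=O)[O-])c1`: > 285000 nM, a limit of the assay and not a number
- Compound 3 `O=C(CSc1ncnn1-c1ccc(Cl)cc1Cl)Nc1ccccc1[N+](=O)[O-]`: 187000 nM

Compound 3 has one numeric neighbour, and the gap to it is small: a 2.0-fold higher number from compound 1 to compound 3 (0.29 log units; within the scatter). Against the limit, the comparison gives an at least 1.5-fold lower number from compound 2 to compound 3 (0.18 log units; that floor lies within the scatter).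

The next change leads to compound 4 `O=C(CSc1ncnn1-c1ccc(Cl)cc1Cl)Nc1ccc(Cl)cc1Br`: 2-bromo-4-chlorophenyl in place of 2-nitrophenyl on an amide-type nitrogen. The measured swap of bromo and nitro bears most directly on this change. Read in reverse, a 2.0-fold higher number from compound 1 to compound 3 (0.29 log units; within the scatter) points to a lower number in this assay, though only weakly. The methyl step concerns a different group and adds little. Among the measured compounds shown here, no measured step covers the chlorine of the entering group, so the estimate stays wide. The expected change is a small one to a lower number: a 2.3-fold lower number from compound 3 to compound 4 (0.37 log units; beyond the scatter). For compound 4 the estimated value is 80000 nM, with an expected range from 25000 nM to 200000 nM.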

Compound 4, half-maximal cytotoxic concentration: 189000 nM
For compound 4 the middle estimate is 2.4-fold (0.37 log units) below the measured one; measured number inside the range.
By their numbers in this assay, from the lowest: compounds 1, 3 and 4 (each within the scatter of the next). At a limit, above all of these: compound 2.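

In this assay, the 2-bromo-4-chlorophenyl group in place of 2-nitrophenyl on an amide-type nitrogen gives a 1.0-fold higher number from compound 3 to compound 4 (0.00 log units; within the scatter). Among the compounds shown here, the chlorine, which no earlier step covered, can now be read on its own: chloro in place of hydrogen on an aromatic carbon gives a 2.0-fold higher number from compound 1 to compound 4 (0.30 log units; within the scatter). Both steps lie within the scatter, so compounds 1, 3 and 4 show that these changes on the aromatic ring, including the full exchange of the group on this nitrogen, do not separate the compounds in this assay.

The compounds shown leave open whether an amine, a carboxylic acid or a longer chain in place of 2-nitrophenyl on an amide-type nitrogen would give a step beyond the scatter. Compound 2 still gives a limit and not a number, which leaves its place open: the limit of > 285000 nM in this assay, at which 1 of the 4 values shown sits.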